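The compounds below may be only part of what the source reports. "The series", "measured", "known", "first", "only" and "open" are said of these compounds alone.

Measured compounds:
compound 1, `COc1ccc(-c2cn3ccnc3c(-c3ccc4ncn(C5CCCCC5)c4c3)n2)cc1`, 69.6%;
compound 2, `O=Cc1ccc(-c2cn3ccnc3c(-c3ccc4ncn(C5CCCCC5)c4c3)n2)cc1`, 46.9%;
compound 3, `CC(=O)c1ccc(-c2cn3ccnc3c(-c3ccc4ncn(C5CCCCC5)c4c3)n2)cc1`, 14.5%.

In a functional assay on LOX IMVI cells (Homo sapiens) for inhibition, read by sulforhodamine B assay, with a stated time of 48 h, tested at 10 uM (on this read-out higher numbers stand for more inhibition at the one concentration tested (going by the name of the read-out) and lower numbers for less inhibition), compound 3 stands lowest of the three; its nearest neighbour is compound 2, because of a number 32.4 percentage points lower from compound 2 to compound 3 (beyond the scatter), and the furthest is compound 1, given a number 55.1 percentage points lower from compound 1 to compound 3 (beyond the scatter). Compound 4, `Brc1ccc(-c2cn3ccnc3c(-c3ccc4ncn(C5CCCCC5)c4c3)n2)cc1`, is not yet measured. Compared with compound 3 it carries bromo in place of acetyl on an aromatic carbon. Going by the values given here, no measured step exchanges acetyl for bromo, so the bearing on this change is indirect: a number 22.7 percentage points lower from compound 1 to compound 2 (beyond the scatter) and a number 55.1 percentage points lower from compound 1 to compound 3 (beyond the scatter) show that replacing methoxy with a carbonyl-bearing group lowered the number, and a number 32.4 percentage points lower from compound 2 to compound 3 (beyond the scatter) shows a large loss on adding a methyl to that carbonyl. Removing the acetyl is therefore expected to recover part of that loss, giving a number 35.5 percentage points higher from compound 3 to compound 4 (beyond the scatter). Compound 4 is estimated at 50%, ranging from 20% to 80%.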

Compound 4, a percentage reported as inhibition, at one concentration (the size of the read-out at that concentration, not a potency): 30.7%
For compound 4 the middle estimate is 19.3 percentage points above the measured one; the range from low to high includes it.
By their numbers in this assay, from the lowest: compound 3; then compound 4; then compound 2; then compound 1.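

In this assay, a carbonyl turns out not to be needed for a drop at this position, since bromo, which has none, also falls short of methoxy: a number 38.9 percentage points lower from compound 1 to compound 4 (beyond the scatter). Bromo is not equal to either carbonyl group, with a number 16.2 percentage points higher from compound 3 to compound 4 (beyond the scatter) and a number 16.2 percentage points lower from compound 2 to compound 4 (beyond the scatter), so the outcome here depends on the particular group and not simply on whether a carbonyl is present. Nothing measured here explains this order. The compounds shown leave open how an amine, a hydroxy group or an ethoxy chain on this aromatic carbon would compare with methoxy.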